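The source may report more compounds than this note shows. Statements on the series, on what has been measured and on what is new or still open speak of the compounds shown alone.

In a functional assay on the whole organism (strain Sprague-Dawley) for inhibition, with Rattus norvegicus as the target (on this read-out lower numbers stand for an effect already at smaller amounts and higher numbers for an effect only at larger amounts of compound), compound 1 `O=c1c(-c2nn[nH]n2)c[nH]c2ccccc12` gives 1.25 mg/kg. Compound 2 `COc1cccc2c(=O)c(-c3nn[nH]n3)c[nH]c12` gives 0.15 mg/kg in this assay, and compound 3 `CC(C)Oc1cccc2c(=O)c(-c3nn[nH]n3)c[nH]c12` gives 0.078 mg/kg. Among these three numbers compound 2 stands second highest: its nearest neighbour is compound 3, separated by a 1.9-fold lower number from compound 2 to compound 3 (0.28 log units; within the scatter), which is within the scatter, and its furthest is compound 1, separated by an 8.3-fold lower number from compound 1 to compound 2 (0.92 log units; beyond the scatter), which is beyond it.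

Compound 4 `COc1ccc(OC)c2c(=O)c(-c3nn[nH]n3)c[nH]c12` has not yet been measured in this assay. It differs from compound 2 by methoxy in place of hydrogen on an aromatic carbon. For the measured compounds named here, the steps that bear on this change are the one from compound 1 to compound 2, an 8.3-fold lower number from compound 1 to compound 2 (0.92 log units; beyond the scatter), and the one from compound 1 to compound 3, a 16-fold lower number from compound 1 to compound 3 (1.20 log units; beyond the scatter); both place methoxy or isopropoxy in place of hydrogen on an aromatic carbon of the core and both lowered the number. Going by the values given here, the new methoxy, however, enters on an aromatic carbon para to a methoxy group, a place for which no measured step exists, so those steps are only a loose guide. A modest lowering, or none beyond the scatter, is therefore expected, amounting to a 1.5-fold lower number from compound 2 to compound 4 (0.18 log units; within the scatter). Compound 4 is estimated to give 0.1 mg/kg in this assay, within a range from 0.03 mg/kg to 0.4 mg/kg.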

Compound 4, minimum effective dose: 1.25 mg/kg
For compound 4 the middle estimate is 13-fold (1.10 log units) below the measured one; measured number outside the range, above it.
By their numbers in this assay, from the lowest: compounds 3 and 2 (each within the scatter of the next); then compounds 1 and 4 (each within the scatter of the next).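

In this assay the same named change, methoxy in place of hydrogen on an aromatic carbon, runs the opposite way at this position: the result is an 8.3-fold higher number from compound 2 to compound 4 (0.92 log units; beyond the scatter), whereas the earlier methoxy gave an 8.3-fold lower number from compound 1 to compound 2 (0.92 log units; beyond the scatter). The lowering seen on the core therefore does not carry over to every aromatic carbon, and on the carbon para to a methoxy group this change raises the number, so the outcome of the change depends on where it is made. Nothing among the data shown explains this reversal.

The compounds shown hold this new methoxy only together with the other one, so it remains open whether the rise belongs to this place alone or to the pair. As far as these compounds go, what a fluorine, an amine or a longer chain would do on this carbon also remains open.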